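Dithiolane versus thiosulfinate on two sugar-like cores

A few compounds are considered here, and "the series" means these few. Any claim that something is new, unique, unknown or untested is made for them only; others in the source may bear on it.

Measured so far:
Compound 1 `CC1(C)O[C@H]([C@H]2COC(C)(C)O2)[C@@H](C2CC(=O)SS2)O1` — 35900 nM
Compound 2 `CC1(C)O[C@H]([C@H]2COC(C)(C)O2)[C@@H](C2CC(=O)S[S+]2[O-])O1` — 18200 nM
Compound 3 `O=C1CC([C@H]2O[C@@H](n3ccc(=O)[nH]c3=O)[C@H](O)[C@@H]2O)SS1` — 62200 nM

All numbers come from a functional assay on HeLa cells (Homo sapiens) for cytotoxicity, read by MTT assay; on this read-out higher numbers stand for weaker inhibition and lower numbers for stronger inhibition. Compound 1 carries the core with two methyl groups; compound 2 differs from it by a group of 7 heavy atoms (3 carbon, 2 oxygen, 2 sulfur; one five-membered non-aromatic ring with 2 hetero atoms) in place of a group of 6 heavy atoms (3 carbon, 1 oxygen, 2 sulfur; one five-membered non-aromatic ring with 2 hetero atoms), on a saturated ring carbon, and that step, a 2.0-fold lower number from compound 1 to compound 2 (0.30 log units; within the scatter), does not leave the scatter. Compound 3 and compound 1 differ in more than one place, so the difference between the two cores is not broken down here; in this assay compound 3 gives 62200 nM, and against compound 1 its number is within the scatter, while against compound 2 it lies beyond it.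

Compound 4 `O=C1CC([C@H]2O[C@@H](n3ccc(=O)[nH]c3=O)[C@H](O)[C@@H]2O)[S+]([O-])S1` is not yet measured. It is obtained from compound 3 by a group of 7 heavy atoms (3 carbon, 2 oxygen, 2 sulfur; one five-membered non-aromatic ring with 2 hetero atoms) in place of a group of 6 heavy atoms (3 carbon, 1 oxygen, 2 sulfur; one five-membered non-aromatic ring with 2 hetero atoms), on a saturated ring carbon. This is the same kind of change as from compound 1 to compound 2, but the place differs: in compound 3 the saturated ring carbon sits on a five-membered non-aromatic ring with 1 oxygen, next to the ring oxygen and next to the ring atom that bears a hydroxy group, whereas in compound 1 it sits on a ring with 2 oxygen, next to the ring atom that bears a group of 7 heavy atoms. Within the data shown here, the step from compound 3 to compound 4 in this assay is expected to be a 2.0-fold lower number from compound 3 to compound 4 (0.30 log units; within the scatter), resting on a 2.0-fold lower number from compound 1 to compound 2 (0.30 log units; within the scatter), the only precedent. Compound 4 is therefore estimated at 31000 nM, between 14000 nM and 80000 nM.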

Compound 4, half-maximal inhibitory concentration: 50700 nM
Compound 4: middle estimate off by 1.6-fold (0.21 log units), on the low side, and the stated range covers the measured number.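

On the core of compound 3, putting the group of 7 heavy atoms in place of the group of 6 heavy atoms gives, in this assay, a 1.2-fold lower number from compound 3 to compound 4 (0.09 log units; within the scatter). Set beside the same change on the core of compound 1, the two steps do not separate: the same change on two cores in this assay, a 2.0-fold lower number (0.30 log units; within the scatter) from compound 1 to compound 2 and a 1.2-fold lower number (0.09 log units; within the scatter) from compound 3 to compound 4, 1.6-fold (0.21 log units) apart, within the scatter of two such steps

Among these compounds, both steps lie within the scatter, so the pair shows only that the change reads alike on these two cores as far as this read-out can resolve; it does not show that the change moves the number on either core, and two cores set no rule for the rest of the series.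

Still open, on these data alone, is how the same change would read on a core carrying an amine, a carboxylic acid or a longer chain in place of the hydroxy groups. Also open, as far as these compounds go, is what a sulfone would give in place of the group of 7 heavy atoms on either core.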